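The source may report more compounds than this note shows. Statements on the series, on what has been measured and on what is new or still open speak of the compounds shown alone.

Measured compounds in a functional assay on cells for agonist activity at C-X-C chemokine receptor type 4 (Homo sapiens), read by fluorescence and calcium flux, with a stated time of 90 s; on this read-out lower numbers stand for an effect already at smaller amounts and higher numbers for an effect only at larger amounts of compound:

Compound 1, `c1ccc2c(c1)CN[C@@H](CN(CCCCNCc1ccncc1)[C@H]1CCCc3cccnc31)C2`: compound 1 gives > 30000 nM, which is a limit of the assay and not a number.
Compound 2, `c1ccc(CNCCCCN(C[C@H]2Cc3ccccc3CN2)[C@H]2CCCc3cccnc32)cc1`: compound 2 gives > 30000 nM, again a limit rather than a number.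
Compound 3, `c1ccc2c(c1)CN[C@@H](CN(CCCCNC1CCSCC1)[C@H]1CCCc3cccnc31)C2`: compound 3 gives > 30000 nM, also a limit and not a number.

Compound 3 therefore stands at the limit of > 30000 nM in this assay, at which 3 of the 3 values shown sit, with nothing to set it apart from the other two measured compounds. The steps among the measured compounds are a step that the two limits leave unreadable from compound 1 to compound 2, a step that the two limits leave unreadable from compound 1 to compound 3 and a step that the two limits leave unreadable from compound 2 to compound 3; none of them can be read, since both ends of each lie at the limit.

Compound 4, `O=S1(=O)CCC(NCCCCN(C[C@H]2Cc3ccccc3CN2)[C@H]2CCCc3cccnc32)CC1`, differs from compound 3 by 1,1-dioxothian-4-yl in place of thian-4-yl on an amine nitrogen. All three measured steps bear on the amine substituent at this position, and all three are unreadable, so they give no direction for the present change. In this assay the step from compound 3 to compound 4 is estimated as a step that the limit leaves unreadable from compound 3 to compound 4, most likely leaving compound 4 at the limit as well. For compound 4 the expected value in this assay is 50000 nM, within a range from 20000 nM to 300000 nM, with a high chance that only a limit is reported.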

Compound 4, half-maximal effective concentration: > 30000 nM
Compound 4: only a limit was reported (the forecaster's own chance of this, stated with the estimate: 85%); the middle value does not contradict the limit.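

In this assay compound 4 gives > 30000 nM, which is a limit and not a number. The steps to compound 4 from compound 1, compound 2 and compound 3 therefore cannot be read. The compounds shown leave open whether any of these amine substituents changes the read-out, since all four stand at one value: the limit of > 30000 nM in this assay, at which 4 of the 4 values shown sit.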